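Working notes: cyano in place of chloro on the shared core

The source may report more compounds than this note shows. Statements on the series, on what has been measured and on what is new or still open speak of the compounds shown alone.

Measured so far in a functional assay on cells for positive allosteric modulation of metabotropic glutamate receptor 2 (Homo sapiens), read by fluorescence and calcium flux, with a stated time of 30 min; a lower number here means that less compound is needed, a higher number that more compound is needed for the effect:
compound 1 `Fc1ccc2c(c1)nnn2Cc1ccc(-c2ccc(Cl)cc2F)nc1`: 68 nM
compound 2 `Brc1ccc(Cn2nnc3c(Br)cccc32)nc1`: 180 nM
compound 3 `Clc1cccc2c1nnn2CC1CC1`: 90 nM

Compound 3 sits second highest among the three numbers in this assay. Compound 1 gives a slightly lower number and compound 2 a higher one, and both gaps to compound 3 lie within the usual scatter of repeated measurements, so the three measured compounds cannot be ordered against one another on this evidence.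

Compound 4 `N#Cc1cccc2c1nnn2CC1CC1` has not yet been measured. It differs from compound 3 in one place: cyano in place of chloro on an aromatic carbon. For the measured compounds named here, no pair of measured compounds shows this kind of change, so there is nothing in the measured set to calibrate it. The expectation for this assay is a small step, if any, with the number for compound 4 somewhat higher than for compound 3 but not clearly beyond the scatter.

The step from compound 3 to compound 4 is estimated at a 1.7-fold higher number from compound 3 to compound 4 (0.22 log units; within the scatter).

Compound 4 is expected to give about 150 nM in this assay, with a likely range from 50 nM to 500 nM.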

Compound 4, half-maximal effective concentration: 620 nM
Beside the measured number, compound 4's estimate is 4.1-fold (0.62 log units) below it, and the stated range ends below it.
By their numbers in this assay, from the lowest: compounds 1, 3 and 2 (each within the scatter of the next, the first and the last beyond it); then compound 4.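

In this assay this aromatic carbon proves sensitive to the group it carries: cyano in place of chloro gives a 6.9-fold higher number from compound 3 to compound 4 (0.84 log units; beyond the scatter). For the compounds shown here, this is the first step that can be read between two compounds differing in one place, and it shows that chloro and cyano are not interchangeable here, with compound 3 needing clearly less compound for the effect than compound 4. Nothing shown gives a reason for the size of this step.

From the compounds shown here alone, whether the loss is particular to cyano or follows any replacement of chloro stays open, and an amine, a methoxy group or a carboxylic acid on this carbon would help to separate the two. Going by these compounds alone, no second pair shows this change, so whether the step keeps its size elsewhere also remains unknown.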